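Chloro on the fused ring system of compound 3

This account rests on a few compounds, and the source may have more. Where it says the series, first, only, none or still open, it means among the compounds named here.

Three analogues of one amide series have been run in a functional assay on PC-3 cells (Homo sapiens) for cytotoxicity, read by MTT assay, with a stated time of 72 h; on this read-out higher numbers stand for weaker inhibition and lower numbers for stronger inhibition. Compound 1 `O=C(Nc1nc2ccc(Cl)cc2s1)c1cn(-c2ccccc2)nc1-c1ccccc1` gives 3690 nM. Compound 2 `O=C(Nc1nc2ccccc2s1)c1cn(-c2ccccc2)nc1-c1ccc(F)cc1` gives 7130 nM. Compound 3 `O=C(Nc1nc2ccccc2s1)c1cn(-c2ccccc2)nc1-c1ccc(Cl)cc1` gives 7750 nM, the highest of the three numbers; compound 2 sits nearest, within the scatter, while compound 1 is further off, beyond the scatter.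

Among the measured compounds shown here, the only measured single-change step, a 1.1-fold higher number from compound 2 to compound 3 (0.04 log units; within the scatter), concerns the pendant phenyl ring and does not touch the fused two-ring system, so it has no direct bearing on the change considered here. Compound 4 `O=C(Nc1nc2ccc(Cl)cc2s1)c1cn(-c2ccccc2)nc1-c1ccc(Cl)cc1` differs from compound 3 by chloro in place of hydrogen on an aromatic carbon. For the measured compounds named here, no measured pair isolates this change. Compound 1 carries the same chloro on the fused system but differs from compound 3 in more than one position, so its values and those of compound 3 can only be set side by side: compound 1 stands lower and compound 3 higher.

On that basis a moderate move to a lower number is expected for compound 4, a 1.7-fold lower number from compound 3 to compound 4 (0.24 log units; within the scatter), with wide uncertainty. Compound 4 is estimated at 4500 nM, in the range 1800 nM to 11000 nM.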

Compound 4, half-maximal inhibitory concentration: 3230 nM
Compound 4: the middle estimate sits 1.4-fold (0.14 log units) above what was measured, within the range that was stated.
By their numbers in this assay, from the lowest: compounds 4, 1, 2 and 3 (each within the scatter of the next, the first and the last beyond it).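

The change from 1,3-benzothiazol-2-yl to 6-chloro-1,3-benzothiazol-2-yl now has a measured pair in this assay (a 2.4-fold lower number from compound 3 to compound 4 (0.38 log units; beyond the scatter)), a modest step beyond the scatter for chloro on the six-membered aromatic ring of the fused system. With chloro already at this position, adding chloro to the pendant phenyl ring gives no readable change (a 1.1-fold lower number from compound 1 to compound 4 (0.06 log units; within the scatter)), so in this pair the number stays within the scatter. No measurement at hand explains the step at the fused system.

Going by these compounds, the step at this position rests on a single pair with a chlorinated pendant phenyl ring, so it remains open whether chloro on the fused system gives a step of similar size with the fluoro-bearing pendant ring of compound 2. On these data alone, it is also open how other groups at this position would compare with chloro, among them methoxy, an amine or a carboxylic acid.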